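The source may hold more compounds than are shown below. What is called first, only, known or untested is meant among the compounds shown, and "the series" means these compounds.

Compound 1 `Cc1cc(Oc2ccccc2OCCn2ccc(=O)[nH]c2=O)c(C)c2cc(C#N)ccc12`: > 100000 nM
Compound 2 `Cc1cc2ccc(C#N)cc2c(C)c1Oc1ccccc1OCCn1ccc(=O)[nH]c1=O`: 5000 nM
Compound 3 `Cc1cc(Oc2ccc(F)cc2OCCn2ccc(=O)[nH]c2=O)c(F)c2cc(C#N)ccc12`: 45000 nM

All three were tested in a toxicity assay on MT2 cells (Homo sapiens) for cytotoxicity, read by MTT assay; on this read-out lower numbers stand for higher toxicity in this test and higher numbers for lower toxicity in this test. Compound 1 gives > 100000 nM, which is a limit of the assay rather than a number (the limit of > 100000 nM in this assay, at which 1 of the 3 values shown sits). Of the two real numbers, compound 3 stands highest, and compound 2 comes out clearly lower, beyond the scatter. Compound 4 `Cc1cc(Oc2ccc(F)cc2OCCn2ccc(=O)[nH]c2=O)c(C)c2cc(C#N)ccc12` differs from compound 3 in one place: methyl in place of fluoro on an aromatic carbon. Among the measured compounds shown here, no measured pair shows this exact change, so its size is unknown; compound 1, which carries methyl at this place and no fluoro on the other ring, sits at a limit in this assay. A modest step toward lower toxicity is expected, a 1.6-fold higher number from compound 3 to compound 4 (0.19 log units; within the scatter). Compound 4 is estimated at 70000 nM, between 25000 nM and 200000 nM.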

Compound 4, half-maximal cytotoxic concentration: > 100000 nM
Compound 4 was reported as a limit; the forecaster's own chance of this, stated with the estimate: 40%; middle value at least 1.4-fold (0.15 log units) from the limit.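

In this assay compound 4 gives > 100000 nM, which is a limit of the assay and not a number. Even so, methyl in place of fluoro on this aromatic carbon now has a direction and a minimum size, toward lower toxicity in this test: an at least 2.2-fold higher number from compound 3 to compound 4 (0.34 log units; beyond the scatter). The step between compound 1 and compound 4 cannot be read, and the true size of the methyl effect stays hidden: the limit of > 100000 nM in this assay, at which 2 of the 4 values shown sit.

Open, on these data alone, is how an amine or a methoxy group on this same aromatic carbon would read in this test.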